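Compound 4: an untested change on the ring amine

The compounds below may be only part of what the source reports. "The series", "measured", "known", "first", "only" and "open" are said of these compounds alone.

The measured compounds:
compound 1, `NC(=O)c1c(NC(=O)c2ccccc2Cl)sc2c1CCN(Cc1c(Cl)cccc1Cl)C2`, in a functional assay on HL-60 cells (Homo sapiens) for antiproliferative activity, with a stated time of 24 h (a higher number here means a weaker inhibitor, a lower number a stronger inhibitor), gives 4850 nM
compound 2, `NC(=O)c1c(NC(=O)c2ccc(C(F)(F)F)cc2)sc2c1CCN(Cc1c(Cl)cccc1Cl)C2`, in this assay gives 10600 nM
compound 3, `NC(=O)c1c(NC(=O)c2cccc([N+](=O)[O-])c2)sc2c1CCN(Cc1c(Cl)cccc1Cl)C2`, in this assay gives 18400 nM

Compound 2 stands second highest of the three numbers; its nearest neighbour is compound 3, within the scatter (a 1.7-fold higher number from compound 2 to compound 3 (0.24 log units; within the scatter)), and its furthest is compound 1, beyond it (a 2.2-fold higher number from compound 1 to compound 2 (0.34 log units; beyond the scatter)). Compound 4, `NC(=O)c1c(NC(=O)c2ccc(C(F)(F)F)cc2)sc2c1CCN(C(=S)Nc1ccccc1Cl)C2`, differs from compound 2 at the amine nitrogen in the ring: a group of 10 heavy atoms (7 carbon, 1 nitrogen, 1 sulfur, 1 chlorine; one six-membered aromatic ring of carbon only) in place of a group of 9 heavy atoms (7 carbon, 2 chlorine; one six-membered aromatic ring of carbon only), on an amine nitrogen in a ring.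

All three measured steps (a 2.2-fold higher number from compound 1 to compound 2 (0.34 log units; beyond the scatter), a 3.8-fold higher number from compound 1 to compound 3 (0.58 log units; beyond the scatter), a 1.7-fold higher number from compound 2 to compound 3 (0.24 log units; within the scatter)) alter only the aryl on the carbonyl carbon; none touches the group on the ring amine. Among the compounds with values here, no measured step therefore bears on the change from compound 2 to compound 4, and the direction cannot be read from these data. The expectation for compound 4 is thus set at a step of a 1.1-fold lower number from compound 2 to compound 4 (0.03 log units; within the scatter), with a wide range. Compound 4 is estimated at 10000 nM, between 2500 nM and 40000 nM.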

Compound 4, half-maximal inhibitory concentration: 36100 nM
The estimate for compound 4 lay 3.6-fold (0.56 log units) below the measured number; the measured number falls inside the stated range.
By their numbers in this assay, from the lowest: compound 1; then compounds 2, 3 and 4 (each within the scatter of the next, the first and the last beyond it).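

Within the data shown here, the earlier compounds differed only in the aryl on the carbonyl carbon, so compound 4 is the first to show that the group on the amine nitrogen in the ring also shifts the number in this assay. Putting the new group, with its double bond outside aromatic rings and its hydrogen-bond donor and acceptor, in place of 2,6-dichlorobenzyl gives a 3.4-fold higher number from compound 2 to compound 4 (0.53 log units; beyond the scatter), a modest step towards a weaker inhibitor. Nothing at hand explains this shift.

The compounds shown leave open which part of the entering group goes with the step, and whether a urea, with oxygen in place of the sulfur, or a plain benzyl on the ring amine would give a lower number. Also open, on these data alone, is whether the step holds with 2-chlorophenyl or 3-nitrophenyl on the carbonyl carbon.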